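Varying the Aryl Group on the Sulfonyl Sulfur

The source may report more compounds than this note shows. Statements on the series, on what has been measured and on what is new or still open speak of the compounds shown alone.

Compound 1 `O=[N+]([O-])c1ccc(S(=O)(=O)NCCCCCCNCc2ccc(Br)cc2)cc1`: 9800 nM in a functional assay on MIA PaCa-2 cells (Homo sapiens) for inhibition, read by MTT assay, with a stated time of 72 h; on this read-out higher numbers stand for weaker inhibition of growth and lower numbers for stronger inhibition of growth
Compound 2 `COc1ccc(S(=O)(=O)NCCCCCCNCc2ccc(Br)cc2)cc1`: 13000 nM in this assay
Compound 3 `O=S(=O)(NCCCCCCNCc1ccc(Br)cc1)c1cc(Cl)cc(Cl)c1`: 12000 nM in this assay

Compound 3 stands second highest of the three numbers in this assay. Its nearest neighbour is compound 2, from which the step is a 1.1-fold lower number from compound 2 to compound 3 (0.03 log units; within the scatter), and its furthest is compound 1, from which the step is a 1.2-fold higher number from compound 1 to compound 3 (0.09 log units; within the scatter). The remaining step, a 1.3-fold higher number from compound 1 to compound 2 (0.12 log units; within the scatter), is likewise within the scatter, so the three aryl groups on the sulfonyl sulfur are not distinguished by this read-out.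

Compound 4 `O=S(=O)(NCCCCCCNCc1ccc(Br)cc1)c1ccc2c(c1)OCC2` is not yet measured. It differs from compound 3 in that (a group of 9 heavy atoms (8 carbon, 1 oxygen; one five-membered non-aromatic ring with 1 hetero atom, one six-membered aromatic ring of carbon only) in place of a group of 8 heavy atoms (6 carbon, 2 chlorine; one six-membered aromatic ring of carbon only), on a sulfonyl sulfur). The three measured steps all exchange the group on the sulfonyl sulfur, and none of them moves the number beyond the scatter, so no step beyond the scatter is expected here either in this assay. The expected step is a 1.1-fold lower number from compound 3 to compound 4 (0.04 log units; within the scatter). Compound 4 is therefore estimated at 11000 nM, with a range from 5000 nM to 25000 nM.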

Compound 4, concentration for 50% growth inhibition: 13000 nM
Beside the measured number, compound 4's estimate is 1.2-fold (0.07 log units) below it; the measured number falls inside the stated range.
By their numbers in this assay, from the lowest: compounds 1, 3, 2 and 4 (each within the scatter of the next).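

With the new group, a five-membered non-aromatic ring with 1 hetero atom joins the six-membered aromatic ring on the sulfonyl sulfur, yet the steps in this assay are a 1.1-fold higher number from compound 3 to compound 4 (0.03 log units; within the scatter), no change at the digits printed from compound 2 to compound 4 (within the scatter) and a 1.3-fold higher number from compound 1 to compound 4 (0.12 log units; within the scatter). The lack of separation seen among the single-ring aryl groups therefore extends to a group with a second ring, and the change from 3,5-dichlorophenyl, which adds a hydrogen-bond acceptor, also leaves the number within the scatter. No measurement is available that bears on this result.

From the compounds shown here alone, it remains open whether any group on the sulfonyl sulfur can move the number beyond the scatter, for instance a cyclohexyl group, a carboxylic acid or an amine. Also open, going by these compounds, is how a change elsewhere in the shared core, such as a longer chain, would read.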